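From Naphthalen-1-yl to 3,4-Difluorophenyl on a Ring Nitrogen

The compounds below may be only part of what the source reports. "The series", "measured", "known", "first", "only" and "open" are said of these compounds alone.

Three compounds have been measured in a functional assay on CHO cells with adenosine receptor A1 (Homo sapiens) as the target, read by cAMP accumulation and immunoassay, with a stated time of 6 min, tested at 1 uM; a higher number here means a weaker effect of the compound at the concentration tested, a lower number a stronger effect:

compound 1 `COc1ccc(N2CCN(Cc3csc(N)c3C(=O)c3ccc(Cl)cc3)CC2)cc1` — -15%
compound 2 `Nc1scc(CN2CCN(c3ccc(OC(F)(F)F)cc3)CC2)c1C(=O)c1ccc(Cl)cc1` — -51%
compound 3 `Nc1scc(CN2CCN(c3cccc4ccccc34)CC2)c1C(=O)c1ccc(Cl)cc1` — 2.9%

Compound 3 stands highest of the three numbers in this assay. Its nearest neighbour is compound 1, separated by a number 17.9 percentage points higher from compound 1 to compound 3 (beyond the scatter), and its furthest is compound 2, separated by a number 53.9 percentage points higher from compound 2 to compound 3 (beyond the scatter); both gaps lie beyond the scatter.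

Compound 4 `Nc1scc(CN2CCN(c3ccc(F)c(F)c3)CC2)c1C(=O)c1ccc(Cl)cc1` differs from compound 3 in one place: 3,4-difluorophenyl in place of naphthalen-1-yl on an amine nitrogen in a ring. The two measured steps that bear on this change are the ones that end at compound 3, a number 17.9 percentage points higher from compound 1 to compound 3 (beyond the scatter) and a number 53.9 percentage points higher from compound 2 to compound 3 (beyond the scatter), in which a substituted phenyl was exchanged for naphthalen-1-yl and the number rose each time, modestly in one case and by a large amount in the other. Compound 4 reverses that exchange, so a step downward from compound 3 is expected, most likely of modest to large size. For the measured compounds named here, no measured step shows a phenyl bearing fluorine on the ring nitrogen, so the size is uncertain. Compound 4 is therefore estimated at -25%, with a range from -55% to 5%, which means an expected step of a number 27.9 percentage points lower from compound 3 to compound 4 (beyond the scatter).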

Compound 4, a percentage reported as activity, at one concentration (the size of the read-out at that concentration, not a potency): -78%
The estimate for compound 4 lay 53 percentage points above the measured number; the measured number lies below the stated range.
By their numbers in this assay, from the lowest: compound 4; then compound 2; then compound 1; then compound 3.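

In this assay, the change on the ring nitrogen proved far larger than either earlier exchange suggested: a number 80.9 percentage points lower from compound 3 to compound 4 (beyond the scatter), with the single aromatic ring of 3,4-difluorophenyl replacing the two rings of naphthalen-1-yl. The substituted phenyls also separate clearly from one another, a number 27 percentage points lower from compound 2 to compound 4 (beyond the scatter) and a number 63 percentage points lower from compound 1 to compound 4 (beyond the scatter), so the number at this position depends on what the phenyl carries and not only on phenyl versus naphthalen-1-yl. No measurement is available to explain these differences.

The compounds shown leave open where an unsubstituted phenyl, a chlorophenyl or a cyanophenyl would fall on the same ring nitrogen. They also leave open whether this order would hold as a potency order, as each number comes from a single concentration.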